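The source may report more compounds than this note shows. Statements on the series, on what has been measured and on what is new or still open speak of the compounds shown alone.

In a functional assay on OVCAR-3 cells (Homo sapiens) for antiproliferative activity, read by spectrophotometry, with a stated time of 2 days (on this read-out lower numbers stand for stronger inhibition of growth and higher numbers for weaker inhibition of growth), three compounds on a shared core have been measured. Compound 1 `COc1ccc(Nc2ncc(C(F)(F)F)c(N3Cc4cccc(N(C)S(C)(=O)=O)c4C3)n2)cc1C(F)(F)F` reads > 30000 nM, which is a limit of the assay and not a number. Compound 2 `Cc1ccc(Nc2ncc(C(F)(F)F)c(N3Cc4cccc(N(C)S(C)(=O)=O)c4C3)n2)c(Cl)c1` reads > 30000 nM, again a limit. Among the measured compounds shown here, compound 3 `COc1cc(Nc2ncc(C(F)(F)F)c(N3Cc4cccc(N(C)S(C)(=O)=O)c4C3)n2)cc(OC)c1` gives 630 nM, the only true number of the three.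

Compound 4 `CN(c1cccc2c1CN(c1nc(Nc3ccc(Cl)c(C(F)(F)F)c3)ncc1C(F)(F)F)C2)S(C)(=O)=O` keeps the core and changes only the aryl group: 4-chloro-3-(trifluoromethyl)phenyl in place of 3,5-dimethoxyphenyl on a nitrogen on an aromatic ring. In words, 4-chloro-3-(trifluoromethyl)phenyl stands in place of 3,5-dimethoxyphenyl on a nitrogen on an aromatic ring.

For the measured compounds named here, two measured steps bear on this change. One is an at least 47-fold lower number from compound 1 to compound 3 (1.67 log units; beyond the scatter), and the other is an at least 47-fold lower number from compound 2 to compound 3 (1.67 log units; beyond the scatter). Both are large and both end at the 3,5-dimethoxyphenyl group, so leaving that group has so far meant a large loss. The step that the two limits leave unreadable from compound 1 to compound 2 adds nothing on size. Compound 1 is the closest guide, since its 4-methoxy-3-(trifluoromethyl)phenyl group also carries a trifluoromethyl, and its step of an at least 47-fold lower number from compound 1 to compound 3 (1.67 log units; beyond the scatter) sets the expectation.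

A large step toward weaker inhibition of growth is therefore expected, and the assay may well return only a limit. The estimated step is a 16-fold higher number from compound 3 to compound 4 (1.20 log units; beyond the scatter). For compound 4 the expected value is 10000 nM, with an estimated range from 1500 nM to 30000 nM.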

Compound 4, concentration for 50% growth inhibition: > 50000 nM
Compound 4 ended at the assay's limit; the forecaster's own chance of this, stated with the estimate: 50%; middle value at least 5.0-fold (0.69 log units) from the limit.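

In this assay the exchange of the aryl group brings an at least 79-fold higher number from compound 3 to compound 4 (1.89 log units; beyond the scatter), so a third group on this nitrogen, one with chloro and trifluoromethyl and without methoxy, also lies far from 3,5-dimethoxyphenyl, and this time the loss is measured directly against compound 3 for the group that enters. Compound 4 sits at a limit of the assay and gives no number: the limit of > 50000 nM in this assay, at which 1 of the 4 values shown sits. Of the four aryl groups shown, 3,5-dimethoxyphenyl alone gives a true number, while the steps among compound 1, compound 2 and compound 4 cannot be read, so these compounds cannot be ranked against one another, and the exchange of chloro for methoxy on an aromatic carbon has no readable effect.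

The compounds shown leave open whether the inhibition of growth seen with compound 3 needs both methoxy groups or would survive with a single one. They also leave open how an aryl group carrying an amine, a morpholine or a carboxylic acid on this nitrogen would read, and whether any such group could give a number lower than that of compound 3.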